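This account rests on a few compounds, and the source may have more. Where it says the series, first, only, none or still open, it means among the compounds named here.

Working notes on the series.

In an assay for inhibition of RAC-alpha serine/threonine-protein kinase (Homo sapiens), read by HTRF, with a stated time of 1 h (a lower number here means a stronger inhibitor, a higher number a weaker inhibitor), compound 2 `Cn1ncc(Cl)c1-c1cc(C(=O)N[C@@H]2CN[C@H](CC(N)=O)C[C@H]2c2ccc(Cl)c(Cl)c2)oc1Cl` gives 3.24 nM. Compound 1 `Cn1ncc(Cl)c1-c1cc(C(=O)N[C@@H]2CN[C@H](CCNS(C)(=O)=O)C[C@H]2c2ccc(F)c(F)c2)oc1Cl` gives 3.29 nM in this assay; the two values sit within the scatter of each other, and compound 2 holds the lower of the two numbers reported as numbers. Compound 3 `O=C(N[C@@H]1CNCC[C@H]1c1ccc(Cl)cc1)c1ccc(-c2ncnc3c2CCC3O)s1` returns only a limit of the assay in this assay, > 1000 nM. That entry, (the limit of > 1000 nM in this assay, at which 1 of the 3 values shown sits), is the only limit in the set. So compound 2 has one neighbour within the scatter and one compound that gives a limit rather than a number.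

Compound 4 `Cn1ncc(Cl)c1-c1cc(C(=O)N[C@@H]2CN[C@H](CC(=O)NC3CCC3)C[C@H]2c2ccc(Cl)c(Cl)c2)oc1Cl` has not yet been measured in this assay. It differs from compound 2 as follows: cyclobutyl in place of hydrogen on an amide-type nitrogen. Among the compounds with values here, no pair of measured compounds differs in one place, so the size of this step cannot be read from any measured step. The step from compound 2 to compound 4 is expected to stay within the usual scatter, in either direction. The expected value for compound 4 in this assay is 5 nM, with a range from 1.5 nM to 15 nM. This estimate means an expected step of a 1.5-fold higher number from compound 2 to compound 4 (0.19 log units; within the scatter).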

Compound 4, half-maximal inhibitory concentration: 7.98 nM
For compound 4 the middle estimate is 1.6-fold (0.20 log units) below the measured one; the measured number falls inside the stated range.
By their numbers in this assay, from the lowest: compounds 2 and 1 (each within the scatter of the next); then compound 4. At a limit, above all of these: compound 3.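

In this assay, the series now has its first step in one place: a 2.5-fold higher number from compound 2 to compound 4 (0.39 log units; beyond the scatter). The amide-type nitrogen of the carbamoylmethyl group therefore carries cyclobutyl with a modest rise in the number, but this single step at a single position sets no trend. Nothing shown here bears on why the number rises.

Open, from the compounds shown here alone, is whether the size of the step follows the size of the group on this nitrogen, which a methyl group, a cyclopropyl ring or a cyclohexyl ring there would test. Also open, going by these compounds, is how the series responds when the carbamoyl group gives way to a carboxylic acid or a primary amine, or when the chain holding it is lengthened.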